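Ethoxy cap on the phenol of compound 2

A few compounds are considered here, and "the series" means these few. Any claim that something is new, unique, unknown or untested is made for them only; others in the source may bear on it.

Compound 1 `CC1CC/C(=N\Nc2ccc(F)cc2)c2ncc(C(=O)O)c(=O)n21` carries fluoro on the aryl hydrazone ring; in a functional assay on the whole organism for inhibition, with Rattus norvegicus as the target (on this read-out lower numbers stand for an effect already at smaller amounts and higher numbers for an effect only at larger amounts of compound), compound 1 gives 12.2 umol/kg. Compound 2 `CC1CC/C(=N\Nc2ccc(O)cc2)c2ncc(C(=O)O)c(=O)n21` is the hydroxy analogue, and in this assay compound 2 gives 1.7 umol/kg. Within the data shown here, the single measured step is a 7.2-fold lower number from compound 1 to compound 2 (0.86 log units; beyond the scatter). Among the measured compounds shown here, on the numbers seen so far compound 2 stands lowest of the two, with compound 1 as its only neighbour at a clearly higher number.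

Compound 3 `CCOc1ccc(N/N=C2\CCC(C)n3c2ncc(C(=O)O)c3=O)cc1` is the next point: the change from compound 2 is ethyl in place of hydrogen on an oxygen on an aromatic ring. For the measured compounds named here, no measured step alkylates the oxygen; the one step available shows only that fluoro to hydroxy moves this assay to a lower number, and compound 3 keeps the oxygen but adds an ethyl on it. Going by the values given here, with no direct precedent, the change is expected to cost part of what the hydroxy gave, so the number for compound 3 is estimated to rise, as a 3.5-fold higher number from compound 2 to compound 3 (0.55 log units; beyond the scatter), landing between compound 2 and compound 1 rather than beyond either. For compound 3 the expected value in this assay is 6 umol/kg, with a range from 2 umol/kg to 20 umol/kg.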

Compound 3, dose for 50% inhibition: 1.6 umol/kg
The estimate for compound 3 lay 3.8-fold (0.57 log units) above the measured number; the whole stated range lies above it.
By their numbers in this assay, from the lowest: compounds 3 and 2 (each within the scatter of the next); then compound 1.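

The oxygen on the aromatic ring takes an ethyl without a readable change in this assay: the step is a 1.1-fold lower number from compound 2 to compound 3 (0.03 log units; within the scatter), so the free hydroxy and the ethoxy cannot be told apart on this read-out, and the hydrogen on that oxygen is not needed for a number at this level in these compounds. Among these compounds, the step of a 7.6-fold lower number from compound 1 to compound 3 (0.88 log units; beyond the scatter) puts ethoxy on the same side of fluoro as hydroxy, so among the three compounds both oxygen-linked groups give lower numbers than fluoro, and no compound goes against this. Nothing at hand bears on why the ethyl leaves the number in place.

Open, as far as these compounds go, is how far this tolerance on the oxygen extends: whether a longer chain such as butyl, a branched isopropyl or a benzyl on the same oxygen stays level with compound 2 or moves away from it. Also open, from the compounds shown here alone, is whether the oxygen itself matters, which an amine or a methyl in place of the hydroxy on that aromatic carbon would address.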